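A few compounds are considered here, and "the series" means these few. Any claim that something is new, unique, unknown or untested is made for them only; others in the source may bear on it.

Among the compounds with values here, compound 1 `CC(O)CNc1nc(-c2ccccc2)nc2c1nnn2Cc1ccccc1F` gives 4800000 nM in an assay on isolated protein for binding affinity to adenosine receptor A1 (Bos taurus) (a lower number here means a stronger inhibitor, a higher number a weaker inhibitor), the lowest of the three numbers so far. Compound 2 `CCCCCCNc1nc(-c2ccccc2)nc2c1nnn2Cc1ccccc1F` gives 25000000 nM in this assay, and compound 3 `COc1ccc(C(=O)Nc2nc(-c3ccccc3)nc3c2nnn3Cc2ccccc2F)cc1` gives 21900000 nM. The steps of a 5.2-fold higher number from compound 1 to compound 2 (0.72 log units; beyond the scatter) and a 4.6-fold higher number from compound 1 to compound 3 (0.66 log units; beyond the scatter) were modest, while a 1.1-fold lower number from compound 2 to compound 3 (0.06 log units; within the scatter) stayed within the scatter; all three swap the group on a nitrogen on an aromatic ring. Within the data shown here, compound 4 `CC(O)CNc1nc(-c2ccccc2)nc2c1nnn2Cc1ccccc1Cl` instead differs from compound 1 by chloro in place of fluoro on an aromatic carbon, a change on the 2-fluorobenzyl group that none of the measured steps touches. Among the measured compounds shown here, with no measured step bearing on that position, no shift beyond the scatter is expected, which means an estimated no change at the digits printed from compound 1 to compound 4 (within the scatter). Compound 4 is therefore estimated at 4800000 nM, in a range from 1500000 nM to 15000000 nM.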

Compound 4, inhibition constant: 32000000 nM
The estimate for compound 4 lay 6.7-fold (0.82 log units) below the measured number; the measured number lies above the stated range.
By their numbers in this assay, from the lowest: compound 1; then compounds 3, 2 and 4 (each within the scatter of the next).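

The 2-fluorobenzyl group is not a silent part of compound 1: putting chloro in place of fluoro on that aromatic carbon gives a 6.7-fold higher number from compound 1 to compound 4 (0.82 log units; beyond the scatter) in this assay. A swap of one heavy atom here thus moves the number by a step also rated modest, like the larger swaps on the nitrogen. Nothing available explains this step.

As far as these compounds go, whether bromo, methyl or a plain benzyl with no group on that ring would give a lower number stays open, as does whether the same change behaves alike with hexyl on the nitrogen.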